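The source may report more compounds than this note shows. Statements on the series, on what has been measured and on what is new or still open speak of the compounds shown alone.

Three compounds built on one shared core were tested in an ADME assay on HEK293 cells (Homo sapiens) for cytotoxicity, read by CCK-8 assay, with a stated time of 48 h; a higher number here means a weaker inhibitor, a lower number a stronger inhibitor. Compound 1 (`COc1ccc(/C=C\c2cc(OC)c(OC)c(OC)c2)cc1OCc1ccc(CN2CCCC[C@H]2C(=O)O)cc1`) gives > 50000 nM as a limit of the assay, not a number. Compound 2 (`COc1ccc(/C=C\c2cc(OC)c(OC)c(OC)c2)cc1OCc1ccc(CN[C@H](C(=O)O)[C@H](C)O)cc1`) gives > 50000 nM as a limit too. From the compounds shown here alone, compound 3 (`COc1ccc(/C=C\c2cc(OC)c(OC)c(OC)c2)cc1OCc1ccc(CN2CC[C@H](C(=O)O)C2)cc1`) also gives only a limit, > 50000 nM, so it stands with the others at the limit of > 50000 nM in this assay, at which 3 of the 3 values shown sit, and its true value is unknown.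

Compound 4 (`COc1ccc(/C=C\c2cc(OC)c(OC)c(OC)c2)cc1OCc1ccc(CO)cc1`) differs from compound 3 in one place, on a saturated chain carbon bound to an aromatic carbon: hydroxy in place of 3-carboxypyrrolidin-1-yl on a saturated chain carbon bound to an aromatic carbon. Within the data shown here, three measured steps bear on this: a step that the two limits leave unreadable from compound 1 to compound 2, a step that the two limits leave unreadable from compound 1 to compound 3 and a step that the two limits leave unreadable from compound 2 to compound 3. None gives a size, and all three swap one carboxy-bearing amine group for another, whereas compound 4 carries no such group. A shift toward a lower number in this assay therefore seems likely, though staying at the limit remains possible. The expected change is an at least 3.3-fold lower number from compound 3 to compound 4 (0.52 log units; beyond the scatter) and is only loosely estimated. Compound 4 is expected at about 15000 nM with an estimated range from 1000 nM to 60000 nM overall.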

Compound 4, half-maximal inhibitory concentration: 37000 nM
Estimate against measurement, compound 4: 2.5-fold (0.39 log units) below; the range from low to high includes it.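

In this assay, among these compounds, compound 4 gives 37000 nM, the only true number so far for a group on this saturated chain carbon bound to an aromatic carbon; the steps among the three earlier compounds cannot be read. Hydroxy in place of each carboxy-bearing amine group gives an at least 1.3-fold lower number from compound 3 to compound 4 (0.13 log units; that floor lies within the scatter), an at least 1.3-fold lower number from compound 2 to compound 4 (0.13 log units; that floor lies within the scatter) and an at least 1.3-fold lower number from compound 1 to compound 4 (0.13 log units; that floor lies within the scatter). Each of these is only a floor, so the real size of the change stays unknown, and all three floors rest on one shared limit: the limit of > 50000 nM in this assay, at which 3 of the 4 values shown sit.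

The hydroxy swap removes the nitrogen and the carboxy group together, so the compounds shown cannot say which of the two matters. A plain pyrrolidin-1-yl group without the carboxy, or a carboxylic acid without the nitrogen, at this same place would separate them.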